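The compounds below may be only part of what the source reports. "The series", "measured", "known", "first", "only" and "open" are said of these compounds alone.

Measured compounds so far:
Compound 1, `COc1ccc(S(=O)(=O)Oc2ccccc2NC(=O)Nc2ccccc2)cc1`: in a functional assay on HCT-15 cells (Homo sapiens) for antiproliferative activity (a lower number here means a stronger inhibitor, a higher number a weaker inhibitor), compound 1 gives > 10000 nM, which is a limit of the assay and not a number.
Compound 2, `COc1ccc(S(=O)(=O)Oc2ccccc2NC(=O)c2ccccn2)cc1`: in this assay compound 2 gives 110 nM.

Compound 2 therefore holds the only number shown in this assay; the other value shown sits at the limit of > 10000 nM in this assay, at which 1 of the 2 values shown sits. For the measured compounds named here, the single measured step is an at least 90-fold lower number from compound 1 to compound 2 (1.95 log units; beyond the scatter), and it shows that what sits on the carbonyl carbon moves the number strongly.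

Compound 3, `COc1ccc(S(=O)(=O)Oc2ccccc2NC(=O)c2cccnc2)cc1`, differs from compound 2 as follows: pyridin-3-yl in place of pyridin-2-yl on a carbonyl carbon. No measured step bears directly on this change; the one step shown compares anilino with pyridin-2-yl, not the two pyridyl isomers, so it sets no size for the present move. With the same atoms joined differently and the rest of the core unchanged, a small to moderate step is expected in this assay, more likely toward a higher number than a lower one, with wide uncertainty.

Compound 3 is thus expected to give 400 nM, in the range 80 nM to 3000 nM, which is an estimated step of a 3.6-fold higher number from compound 2 to compound 3 (0.56 log units; beyond the scatter).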

Compound 3, half-maximal inhibitory concentration: > 3000 nM
Compound 3: a limit, no number; the forecaster's own chance of this, stated with the estimate: 10%; middle value at least 7.5-fold (0.87 log units) from the limit.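

In this assay, the earlier step showed only that exchanging anilino for pyridin-2-yl on the carbonyl carbon moves the number; the exchange between the two pyridyl isomers, with the same atoms joined differently, now gives an at least 27-fold higher number from compound 2 to compound 3 (1.43 log units; beyond the scatter), so a pyridine ring at this place is not enough on its own to keep the low number seen with pyridin-2-yl. The value of compound 3 is a limit of the assay and not a number: the limit of > 3000 nM in this assay, at which 1 of the 3 values shown sits.

The step from compound 1 to compound 3 cannot be read, as both values are limits.

Open, as far as these compounds go, is where the true value of compound 3 lies beyond its limit, and with it the full size of the isomer effect in this assay. Also open, from the compounds shown here alone, is whether pyridin-4-yl or plain phenyl on the same carbonyl carbon would stay close to pyridin-2-yl or fall off as pyridin-3-yl does, and whether a methyl group or an amine on the pyridin-2-yl ring would keep the number.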